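This account rests on a few compounds, and the source may have more. Where it says the series, first, only, none or still open, it means among the compounds named here.

Measured in a functional assay on HepG2 cells (Homo sapiens) for inhibition, read by MTT assay, with a stated time of 72 h; on this read-out higher numbers stand for weaker inhibition and lower numbers for stronger inhibition:

- compound 1, `C#CCSc1nc(NCCC#N)c2ccncc2n1`: > 80000 nM
- compound 2, `C#CCSc1nc(Nc2ccccc2)c2ccncc2n1`: 29400 nM

Of the compounds shown here, two with a shared core have been tested so far. In this assay compound 1 gives > 80000 nM, which is a limit of the assay rather than a number (the limit of > 80000 nM in this assay, at which 1 of the 2 values shown sits). For the measured compounds named here, compound 2 stands as the only real number among the two values, since the other is a limit. Going by the values given here, the one measured step, an at least 2.7-fold lower number from compound 1 to compound 2 (0.43 log units; beyond the scatter), comes from replacing 2-cyanoethyl with phenyl on a nitrogen attached to the core.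

Compound 3, `C#CCSc1nc(Nc2ccc(C)cc2)c2ccncc2n1`, has not yet been measured. It differs from compound 2 by methyl in place of hydrogen on an aromatic carbon. Among the compounds with values here, no measured step concerns a change on the phenyl itself; the only measured step, an at least 2.7-fold lower number from compound 1 to compound 2 (0.43 log units; beyond the scatter), swaps the whole group on the nitrogen and so does not directly bear on a methyl on that ring. In this assay no step beyond the scatter is therefore expected for this small change. Compound 3 is estimated at 25000 nM, within 8000 nM to 80000 nM, which corresponds to an expected step of a 1.2-fold lower number from compound 2 to compound 3 (0.07 log units; within the scatter).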

Compound 3, half-maximal inhibitory concentration: 6170 nM
Compound 3: the middle estimate sits 4.1-fold (0.61 log units) above what was measured; the measured number lies below the stated range.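

In this assay, the change from phenyl to 4-methylphenyl gives a 4.8-fold lower number from compound 2 to compound 3 (0.68 log units; beyond the scatter), so a single added carbon on this ring, para to a large group, is enough to move the number beyond the scatter; the earlier compounds had shown only the effect of swapping the entire group on the nitrogen. Swapping the 2-cyanoethyl group for 4-methylphenyl gives an at least 12-fold lower number from compound 1 to compound 3 (1.11 log units; beyond the scatter), which is a lower bound on the size of the step and not an exact size. The value of compound 1 is a limit of the assay and not a number: the limit of > 80000 nM in this assay, at which 1 of the 3 values shown sits.

With methyl as the only group shown on this ring, it stays open whether the lower number is particular to methyl or would also come with an ethyl group, a chlorine atom or a carboxylic acid on the same carbon. Also open, on these data alone, are whether methyl on another carbon of the ring would give a similar step, and what lies behind the step itself.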